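This account rests on a few compounds, and the source may have more. Where it says the series, first, only, none or still open, it means among the compounds named here.

Measured so far:
compound 1, `CCN(CC)c1cc2[nH]c(C3CCCCC3)nc2cc1NC(=O)OCCOCCOC`: > 100 ug/mL
compound 2, `CN(C)c1cc2[nH]c(C3CCCCC3)nc2cc1NC(=O)c1cccs1`: > 100 ug/mL
compound 3, `CCCCOC(=O)Nc1cc2nc(C3CCCCC3)[nH]c2cc1N(C)C`: > 100 ug/mL

In an ADME assay on Vero cells (Chlorocebus sabaeus) for cytotoxicity, read by resazurin assay, with a stated time of 3 days (a lower number here means a stronger inhibitor, a higher number a weaker inhibitor), compound 1 gives > 100 ug/mL, which is a limit of the assay and not a number. Compound 2 likewise gives a limit, > 100 ug/mL. Compound 3 also gives a limit, > 100 ug/mL. All three values are covered by the limit of > 100 ug/mL in this assay, at which 3 of the 3 values shown sit, so compound 1 cannot be placed above or below the other two; it simply stands with them at the limit. Within the data shown here, the single step between measured compounds that differ in one place, a step that the two limits leave unreadable from compound 2 to compound 3, is itself unreadable for the same reason, and no measured step addresses the change now in question.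

Compound 4, `CCN(CC)c1cc2[nH]c(C3CCCCC3)nc2cc1NC(=O)c1ccc(F)cc1F`, has not yet been measured. It differs from compound 1 by 2,4-difluorophenyl in place of 2-(2-methoxyethoxy)ethoxy on a carbonyl carbon. With every value shown sitting at the limit, there is no measured movement to carry over, and the step expected in this assay from compound 1 to compound 4 is none beyond the scatter, a number no higher from compound 1 to compound 4 (the limit leaves the size open). Compound 4 is therefore expected to give 100 ug/mL, in a range from 40 ug/mL to 300 ug/mL, most likely again reported only as a limit.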

Compound 4, half-maximal inhibitory concentration: > 100 ug/mL
Compound 4: a limit, no number; the forecaster's own chance of this, stated with the estimate: 80%; the middle value sits exactly at the limit.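

In this assay compound 4 gives > 100 ug/mL, a limit of the assay and not a number, and no step can be read for the change from compound 1 to compound 4. The compounds shown leave open whether any change among them moves the read-out at all: the limit of > 100 ug/mL in this assay, at which 4 of the 4 values shown sit.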